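Adding a methoxy group to compound 2

A few compounds are considered here, and "the series" means these few. Any claim that something is new, unique, unknown or untested is made for them only; others in the source may bear on it.

Among the compounds with values here, in a functional assay on KB cells (Homo sapiens) for antiproliferative activity, read by sulforhodamine B assay, with a stated time of 72 h (a lower number here means a stronger inhibitor, a higher number a weaker inhibitor), compound 2 (`COc1ccc(C(=O)/C=C/c2csc3ccccc23)c(O)c1`) gives 5600 nM, the higher of the two numbers so far. Compound 1 (`COc1ccc(O)c(C(=O)/C=C/c2csc3ccccc23)c1`) gives 640 nM, a lower number, with the gap beyond the scatter. Compound 3 (`COc1cc(O)c(C(=O)/C=C/c2csc3ccccc23)cc1OC`) arises from compound 2 by methoxy in place of hydrogen on an aromatic carbon, ortho to a methoxy group and para to a hydroxy group. Within the data shown here, no measured step shows this change alone. The lower value of compound 1, 640 nM, points to a gain. The expected change, toward a lower number, is a 3.7-fold lower number from compound 2 to compound 3 (0.57 log units; beyond the scatter). For compound 3 the estimated value is 1500 nM, with an expected range of 350 nM to 6000 nM.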

Compound 3, half-maximal inhibitory concentration: 520 nM
For compound 3 the middle estimate is 2.9-fold (0.46 log units) above the measured one; measured number inside the range.
By their numbers in this assay, from the lowest: compounds 3 and 1 (each within the scatter of the next); then compound 2.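

In this assay methoxy in place of hydrogen, ortho to a methoxy group and para to a hydroxy group, brings an 11-fold lower number from compound 2 to compound 3 (1.03 log units; beyond the scatter) and so marks this position as one where a small ether gives a large gain. The same kind of replacement read from the other parent gives a 1.2-fold lower number from compound 1 to compound 3 (0.09 log units; within the scatter) and stays within the scatter, so the gain depends on the parent and does not follow from adding methoxy alone. Nothing measured here accounts for this difference. As far as these compounds go, whether ethoxy, fluorine or an amine at this carbon would keep the gain remains open.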